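Exchanging the Aromatic Ring on a Shared Core

The source may hold more compounds than are shown below. What is called first, only, known or untested is meant among the compounds shown, and "the series" means these compounds.

Compound 1 `CCCCCCCCc1ccc(OCC(=O)Cn2nnc(-c3ccccc3Cl)n2)cc1`: in an assay on microsomes from brain for inhibition of Fatty-acid amide hydrolase 1 (Rattus norvegicus), read by fluorescence and HPLC, with a stated time of 60 min (on this read-out higher numbers stand for weaker inhibition and lower numbers for stronger inhibition), compound 1 gives 32 nM
Compound 2 `CCCCCCCCc1ccc(OCC(=O)Cn2nnc(-c3ccncc3)n2)cc1`: in this assay compound 2 gives 24 nM

Within the data shown here, compound 2 has the lower of the two numbers so far; compound 1 is nearest, and the step of a 1.3-fold lower number from compound 1 to compound 2 (0.12 log units; within the scatter) lies within the scatter, so the two are not distinguishable. Compound 3 `CCCCCCCCc1ccc(OCC(=O)Cn2nnc(-c3cccs3)n2)cc1` differs from compound 2 by thiophen-2-yl in place of pyridin-4-yl on an aromatic carbon. Among the measured compounds shown here, the only measured step that bears on this, a 1.3-fold lower number from compound 1 to compound 2 (0.12 log units; within the scatter), also exchanged the ring at the same position and stayed within the scatter. No step beyond the scatter is therefore expected in this assay. Compound 3 is estimated to give 25 nM, with a range from 10 nM to 65 nM, which is an expected step of a 1.0-fold higher number from compound 2 to compound 3 (0.02 log units; within the scatter).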

Compound 3, half-maximal inhibitory concentration: 32 nM
The estimate for compound 3 lay 1.3-fold (0.11 log units) below the measured number; the measured number falls inside the stated range.
By their numbers in this assay, from the lowest: compounds 2, 1 and 3 (each within the scatter of the next).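

In this assay, the five-membered thiophen-2-yl ring cannot be told apart from either six-membered ring on the shared core: replacing pyridin-4-yl gives (a 1.3-fold higher number from compound 2 to compound 3 (0.12 log units; within the scatter)), and replacing 2-chlorophenyl gives (in this comparison, no change at the digits printed from compound 1 to compound 3 (within the scatter)). Across these three compounds, the ring at this position changed in size and in its hetero atom, yet every step stayed within the scatter. Nothing available explains this result.

From the compounds shown here alone, whether a non-aromatic group at this position, such as an amine, a carboxylic acid or a cyclohexyl ring, would give a similar number remains open.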